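Replacing 4-cyanobutyl with pyridin-2-yl in compound 3

A few compounds are considered here, and "the series" means these few. Any claim that something is new, unique, unknown or untested is made for them only; others in the source may bear on it.

Measured so far in a physicochemical assay for solubility, in phosphate buffer, with a stated time of 18 h; on this read-out lower numbers stand for lower solubility and higher numbers for higher solubility:
compound 1 `CC(C)(C)c1ccc2c(N)c(C#N)c(N)nc2n1`: 14200 nM
compound 2 `N#Cc1c(N)nc2nc(C3CCCC3)ncc2c1N`: 89000 nM
compound 3 `CC(C)(C)c1nc(CCCCC#N)c2c(N)c(C#N)c(N)nc2n1`: 16000 nM

Of these three numbers, compound 3 at 16000 nM lies within the usual scatter of compound 1 at 14200 nM. Compound 2 at 89000 nM stands higher than compound 3, by a gap beyond the scatter.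

The next compound is compound 4 `CC(C)(C)c1nc(-c2ccccn2)c2c(N)c(C#N)c(N)nc2n1`, which carries pyridin-2-yl in place of 4-cyanobutyl on an aromatic carbon, opposite the ring nitrogen. The counted difference is pyridin-2-yl in place of 4-cyanobutyl on an aromatic carbon. Within the data shown here, no two measured compounds differ in only one place, and none of them shows this exchange, so the data offer no direct guide to its size. A moderate fall in this assay is expected, and it may not lie far beyond the scatter. The expected change is estimated as a 1.8-fold lower number from compound 3 to compound 4 (0.25 log units; within the scatter). For compound 4 the estimated value is 9000 nM, with an expected range from 2500 nM to 30000 nM.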

Compound 4, solubility: 87000 nM
Compound 4: middle estimate off by 9.7-fold (0.99 log units), on the low side; measured number above the stated range.
By their numbers in this assay, from the lowest: compounds 1 and 3 (each within the scatter of the next); then compounds 4 and 2 (each within the scatter of the next).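

In this assay there is a 5.4-fold higher number from compound 3 to compound 4 (0.74 log units; beyond the scatter) when pyridin-2-yl takes the place of 4-cyanobutyl on the aromatic carbon opposite the ring nitrogen, so what this position carries can move the read-out beyond the scatter. The two groups have the same counts of heavy atoms, carbon, nitrogen, donors and acceptors, and these counts alone therefore do not fix the number here; what differs is an open chain with a triple bond against a six-membered aromatic ring. Nothing measured in the material at hand accounts for the rise.

As far as these compounds go, whether the nitrogen of the pyridin-2-yl ring matters remains open, and a phenyl group at this position would speak to that. A plain butyl chain would likewise separate the chain itself from its nitrile.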